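The compounds below may be only part of what the source reports. "The series", "measured", "known", "first", "only" and "open" are said of these compounds alone.

Compound 1, `Nc1scc(CN2CCN(c3cccc(Cl)c3Cl)CC2)c1C(=O)c1ccc(Cl)cc1`, sits at the foot of the three numbers shown, though its separation from both neighbours stays within the scatter. In an assay on CHO cells for displacement of a labelled ligand from adenosine receptor A3 (Homo sapiens), read by scintillation counting, with a stated time of 120 min, tested at 10 uM (a lower number here means less inhibition, a higher number more inhibition at the concentration tested (going by the name of the read-out)), compound 1 gives 0%. Compound 2, `Nc1scc(CN2CCN(c3ccc([N+](=O)[O-])cc3)CC2)c1C(=O)c1ccc(Cl)cc1`, gives 2% in this assay, and compound 3, `Nc1scc(CN2CCN(c3ccc(OC(F)(F)F)cc3)CC2)c1C(=O)c1ccc(Cl)cc1`, gives 1%. The steps between them are small: a number 2 percentage points higher from compound 1 to compound 2 (within the scatter), a number 1 percentage points higher from compound 1 to compound 3 (within the scatter) and a number 1 percentage points lower from compound 2 to compound 3 (within the scatter).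

Compound 4, `Nc1scc(CN2CCN(c3ccc(F)cc3F)CC2)c1C(=O)c1ccc(Cl)cc1`, has not been measured. It differs from compound 1 in one place: 2,4-difluorophenyl in place of 2,3-dichlorophenyl on an amine nitrogen in a ring. Within the data shown here, two measured steps bear on this change, since both exchange the same 2,3-dichlorophenyl on the amine nitrogen in the ring for another aryl group: a number 2 percentage points higher from compound 1 to compound 2 (within the scatter) and a number 1 percentage points higher from compound 1 to compound 3 (within the scatter), each within the scatter. On that basis compound 4 is expected to show no step beyond the scatter, a number 1 percentage points higher from compound 1 to compound 4 (within the scatter). The estimate for compound 4 in this assay is 1%, with a range from 0% to 10%.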

Compound 4, a percentage reported as inhibition, at one concentration (the size of the read-out at that concentration, not a potency): 0%
Compound 4: the middle estimate sits 1 percentage points above what was measured; the measured number falls inside the stated range.
By their numbers in this assay, from the lowest: compounds 1, 4, 3 and 2 (each within the scatter of the next).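

At the aryl group on the amine nitrogen in the ring, a third replacement of 2,3-dichlorophenyl, this time by 2,4-difluorophenyl, again produces no separation in this assay: the result is no change at the digits printed from compound 1 to compound 4 (within the scatter), alongside a number 1 percentage points lower from compound 3 to compound 4 (within the scatter) and a number 2 percentage points lower from compound 2 to compound 4 (within the scatter). A fluorine-bearing phenyl thus joins the chlorine-, nitro- and trifluoromethoxy-bearing phenyl groups, and none of the four stands apart from another. No supporting measurement is available to account for this flat outcome.

All four compounds carry a substituted phenyl group at this nitrogen, so the compounds shown leave open whether any other kind of group there would give a number beyond the scatter. A phenyl bearing an amine or a carboxylic acid, or a longer alkyl chain in place of the phenyl, remains an open case.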